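The source may report more compounds than this note shows. Statements on the series, on what has been measured and on what is new or still open speak of the compounds shown alone.

Compound 1 `CCN(CC)CCNC(=O)c1ccc(C(CC)(CC)c2ccc(OCCC(O)(CC)CC)c(C)c2)n1CC`: 2290 nM
Compound 2 `CCn1c(C(=O)Nc2cccc(C(F)(F)F)c2)ccc1C(CC)(CC)c1ccc(OCCC(O)(CC)CC)c(C)c1`: > 50000 nM

In an ADME assay on L02 cells (Homo sapiens) for antiproliferative activity, read by MTT assay, with a stated time of 48 h (a lower number here means a stronger inhibitor, a higher number a weaker inhibitor), compound 2 gives only a limit of the assay, > 50000 nM, and no exact number. Compound 3 `CCOc1ccc(NC(=O)c2ccc(C(CC)(CC)c3ccc(OCCC(O)(CC)CC)c(C)c3)n2CC)cc1` carries 4-ethoxyphenyl in place of 3-(trifluoromethyl)phenyl on an amide-type nitrogen. Within the data shown here, the one measured step on this nitrogen, an at least 21-fold higher number from compound 1 to compound 2 (1.33 log units; beyond the scatter), was large and brought in 3-(trifluoromethyl)phenyl in place of 2-(diethylamino)ethyl. Compound 3 keeps a six-membered aromatic ring of carbon only there, so no step beyond the scatter is expected in this assay. The expected step is an at least 1.2-fold lower number from compound 2 to compound 3 (0.09 log units; that floor lies within the scatter). For compound 3 the estimated value is 40000 nM, with an expected range of 12000 nM to 100000 nM.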

Compound 3, half-maximal inhibitory concentration: > 50000 nM
Compound 3 was reported as a limit; the forecaster's own chance of this, stated with the estimate: 55%; at least 1.2-fold (0.09 log units) between middle value and limit.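

In this assay, 4-ethoxyphenyl in place of 2-(diethylamino)ethyl on the amide-type nitrogen gives an at least 21-fold higher number from compound 1 to compound 3 (1.33 log units; beyond the scatter), so the large step seen for compound 2 is not confined to the 3-(trifluoromethyl)phenyl group. The step between compound 2 and compound 3 cannot be read, since both results are limits of the assay and not numbers: the limit of > 50000 nM in this assay, at which 2 of the 3 values shown sit.

Going by these compounds, it remains open whether any aromatic group on this nitrogen gives a readable value, such as a pyridine ring carrying a basic amine. A longer chain ending in an amine, such as 3-(diethylamino)propyl, is also untested among the compounds shown.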